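The source may hold more compounds than are shown below. What is called first, only, known or untested is meant among the compounds shown, and "the series" means these compounds.

Measured in an ADME assay on RAW264.7 cells (Mus musculus) for cytotoxicity, read by MTT assay, with a stated time of 24 h, tested at 10 ug/mL; on this read-out higher numbers stand for a weaker effect at the one concentration tested and lower numbers for a stronger effect:
- compound 1, `COc1ccc(CCCc2ccc(OC)cc2OC)c(O)c1` — 25.8%
- compound 2, `COc1ccc(C(=O)/C=C/c2ccc(OC)c(OC)c2OC)c(O)c1` — 75.3%
- compound 3, `COc1ccc(C(=O)/C=C/c2cccc(OC)c2OC)c(O)c1` — 60.3%

Compound 1 gives the lowest of the three numbers in this assay; compound 3 stands nearest to it and compound 2 furthest, both beyond the scatter. Compound 2 and compound 3 are a measured pair: a number 15 percentage points higher from compound 3 to compound 2 (beyond the scatter). The change there is methoxy in place of hydrogen on an aromatic carbon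

Compound 4, `COc1ccc(CCCc2ccc(OC)c(OC)c2OC)c(O)c1`, is not yet measured in this assay. It is compound 1 with the same kind of change: methoxy in place of hydrogen on an aromatic carbon

The place is not the same word for word: in compound 4 the entering group sits ortho to two methoxy groups and meta to a large group, whereas in compound 2 it sits ortho to a methoxy group, meta to a methoxy group and para to a large group. The difference between the two cores, that of compound 1 and that of compound 3, is not broken down here.

Going by the values given here, with only one measured instance of this kind of change, the expectation for compound 4 rests on that single pair, compound 3 and compound 2. A step of roughly the same size is expected here, a number 14.2 percentage points higher from compound 1 to compound 4 (beyond the scatter), so that the number moves up from a low starting point. Compound 4 is expected to give about 40% in this assay, plausibly between 26% and 58%.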

Compound 4, a percentage reported as activity, at one concentration (the size of the read-out at that concentration, not a potency): 36.7%
For compound 4 the middle estimate is 3.3 percentage points above the measured one; the range from low to high includes it.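

In this assay methoxy in place of hydrogen on an aromatic carbon gives a number 10.9 percentage points higher from compound 1 to compound 4 (beyond the scatter) and so moves the number in the same direction on the core of compound 1 as on the core of compound 3, towards a weaker effect at the one concentration tested. This rests on two pairs only, with the entering group in a different place in each, so it does not show that the step holds on other cores or at other places, and it does not separate the contribution of the cores themselves. Within these two pairs the change carries over with a similar size: the same change on two cores in this assay, a number 15 percentage points higher (beyond the scatter) from compound 3 to compound 2 and a number 10.9 percentage points higher (beyond the scatter) from compound 1 to compound 4, 4.1 percentage points apart, within the scatter of two such steps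

Whether the step depends on the entering group itself stays open, since methoxy is the only group shown in this change, and an amine or a carboxylic acid on the same aromatic carbon could show that. A longer chain linking the two aromatic parts of the core of compound 1 is also left open.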